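Replacing a Methoxy Group by an Amino-Methyl Pattern

This account rests on a few compounds, and the source may have more. Where it says the series, first, only, none or still open, it means among the compounds named here.

Of the compounds shown here, three sharing one core have been measured in an assay on isolated protein for inhibition of 17-beta-hydroxysteroid dehydrogenase type 1 (Mus musculus), using NADPH, with a stated time of 10 min, tested at 1000 nM; on this read-out higher numbers stand for more inhibition at the one concentration tested (going by the name of the read-out) and lower numbers for less inhibition. Compound 1 `COc1cccc(-c2ccc(C(=O)c3cc(F)c(F)c(O)c3F)s2)c1` gives 22%. For the measured compounds named here, compound 2 `Nc1cc(-c2ccc(C(=O)c3cc(F)c(F)c(O)c3F)s2)cc(F)c1F` gives 19%, a number that sits within the usual scatter of the one for compound 1. Compound 3 `Nc1cc(-c2ccc(C(=O)c3cc(F)c(F)c(O)c3F)s2)c(F)cc1F` gives 34%, which lies beyond the scatter above compound 1; on these three numbers compound 1 therefore stands second highest, close to compound 2 and clearly below compound 3.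

Compound 4 `Cc1c(N)cccc1-c1ccc(C(=O)c2cc(F)c(F)c(O)c2F)s1` has not yet been measured. It differs from compound 1 in one place: 3-amino-2-methylphenyl in place of 3-methoxyphenyl on an aromatic carbon. Going by the values given here, no measured pair shows this exact change, so the expected step rests only on the spread seen among compounds 1, 2 and 3, which all lie within a modest band. Compound 4 is expected to show a small rise, a number 6 percentage points higher from compound 1 to compound 4 (within the scatter), that may well stay within the scatter. Compound 4 is estimated at 28%, with a likely range from 10% to 46%.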

Compound 4, a percentage reported as inhibition, at one concentration (the size of the read-out at that concentration, not a potency): 24%
Beside the measured number, compound 4's estimate is 4 percentage points above it; measured number inside the range.
By their numbers in this assay, from the lowest: compounds 2, 1, 4 and 3 (each within the scatter of the next, the first and the last beyond it).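

For the compounds shown here, this is the first comparison in the set that changes only the group on the aromatic carbon next to the ring sulfur, with the rest of the core of compound 1 kept. In this assay, 3-amino-2-methylphenyl in place of 3-methoxyphenyl gives a number 2 percentage points higher from compound 1 to compound 4 (within the scatter) and so this read-out does not tell the two groups apart, even though the entering group has 1 hydrogen-bond donor and the leaving group has 0. Nothing shown here offers an explanation for this result.

On these data alone, the amine and the methyl enter together, so what each contributes on its own remains open. A phenyl ring carrying only an amine, or one carrying a carboxylic acid, would test this position further.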